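This account rests on a few compounds, and the source may have more. Where it says the series, first, only, none or still open, it means among the compounds named here.

Compound 1 `CC(C)c1onc(-c2ccccc2Cl)c1COc1ccc(CCCC(=O)O)cc1` gives 3800 nM in an assay on HEK-293T cells for activation of Bile acid receptor (Homo sapiens), read by a luciferase reporter, with a stated time of 14 h; a lower number here means that less compound is needed, a higher number that more compound is needed for the effect.
Compound 2 `CC(C)c1onc(-c2ccccc2)c1COc1ccc(CCCC(=O)O)cc1` gives 31000 nM in this assay.
Compound 3 `Cc1cccc(C)c1-c1noc(C(C)C)c1COc1ccc(CCCC(=O)O)cc1` gives 7700 nM in this assay.

Compound 1 shows the lowest number of the three: a 2.0-fold higher number from compound 1 to compound 3 (0.31 log units; beyond the scatter) and an 8.2-fold higher number from compound 1 to compound 2 (0.91 log units; beyond the scatter), both beyond the scatter. Compound 4 `CC(C)c1onc(-c2ccccc2Cl)c1COc1ccc(COc2ccc(CC(=O)O)cc2)cc1` keeps the 2-chlorophenyl of compound 1 and changes the acid-bearing side instead: 4-(carboxymethyl)phenoxy in place of 2-carboxyethyl on a saturated chain carbon bound to an aromatic carbon. The measured steps all concern the aryl group and not the acid side, so none bears directly on this change. With no guide, about no step beyond the scatter is expected, as a 1.5-fold lower number from compound 1 to compound 4 (0.18 log units; within the scatter), with wide uncertainty. Compound 4 is therefore estimated at 2500 nM, within 500 nM to 12000 nM.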

Compound 4, half-maximal effective concentration: 2500 nM
Compound 4: the middle estimate sits on the measured number at the digits printed; low and high end bracket the measured number.
By their numbers in this assay, from the lowest: compounds 4 and 1 (each within the scatter of the next); then compound 3; then compound 2.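

Replacing the 2-carboxyethyl of compound 1 with 4-(carboxymethyl)phenoxy gives a 1.5-fold lower number from compound 1 to compound 4 (0.18 log units; within the scatter) in this assay. Unlike the earlier steps, which concern only the aryl group, this one shows that the acid-bearing side can gain a six-membered aromatic ring, going from 5 to 11 heavy atoms, without a step beyond the scatter. Nothing available explains this result.

Within the data shown here, whether the acid end matters remains open, as no compound here carries an amide in its place. Also open, from the compounds shown here alone, is whether the phenyl and 2,6-dimethylphenyl groups would keep their order with this new side chain.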